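Same Sulfonyl Aryl Swap on the Isomeric Core

A few compounds are considered here, and "the series" means these few. Any claim that something is new, unique, unknown or untested is made for them only; others in the source may bear on it.

The measured compounds and their values:
compound 1 `Cc1ccccc1C(=O)c1cnc(NCCCNS(=O)(=O)c2cccc(F)c2)s1` gives 5.5 nM
compound 2 `Cc1ccccc1C(=O)c1cnc(NCCCNS(=O)(=O)c2cc(C(F)(F)F)ccc2Cl)s1` gives 0.85 nM
compound 3 `Cc1ccccc1C(=O)c1csc(NCCCNS(=O)(=O)c2cccc(F)c2)n1` gives 64 nM

All three were tested in an assay on isolated protein for inhibition of Neuropeptide Y receptor type 5 (Mus musculus); on this read-out lower numbers stand for stronger inhibition and higher numbers for weaker inhibition. Among these three numbers, compound 3 stands highest: in this assay compound 3 gives 64 nM, whereas compound 1 gives 5.5 nM and compound 2 gives 0.85 nM, so compound 3 is the weakest of the three, with the gap to compound 2 wider than the gap to compound 1.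

Compound 4 `Cc1ccccc1C(=O)c1csc(NCCCNS(=O)(=O)c2cc(C(F)(F)F)ccc2Cl)n1` has not yet been measured. It differs from compound 3 in one place: 2-chloro-5-(trifluoromethyl)phenyl in place of 3-fluorophenyl on a sulfonyl sulfur. The same exchange has been seen once before, on the other arrangement of the shared core, as the step from compound 1 to compound 2, where it produced a 6.5-fold lower number from compound 1 to compound 2 (0.81 log units; beyond the scatter). Among the compounds with values here, that is the only measured step bearing on this change, and it was of modest size in the direction of stronger inhibition.

On that basis the change is expected to move compound 4 in the same direction and by a comparable amount: in this assay compound 4 is expected to give 10 nM, within a range from 4 nM to 30 nM. Within the data shown here, the expected step from compound 3 to compound 4 is therefore a 6.4-fold lower number from compound 3 to compound 4 (0.81 log units; beyond the scatter), resting on the single precedent of compound 1 to compound 2 and so carrying real uncertainty.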

Compound 4, half-maximal inhibitory concentration: 9 nM
Compound 4: middle estimate off by 1.1-fold (0.05 log units), on the high side, within the range that was stated.
By their numbers in this assay, from the lowest: compound 2; then compounds 1 and 4 (each within the scatter of the next); then compound 3.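

Before this result, the exchange of 3-fluorophenyl for 2-chloro-5-(trifluoromethyl)phenyl on a sulfonyl sulfur had been seen on only one arrangement of the shared core, and a single step cannot show whether a gain travels to another core. In this assay, the exchange on the second arrangement gives a 7.1-fold lower number from compound 3 to compound 4 (0.85 log units; beyond the scatter), which shows that the gain is not confined to the first arrangement, even though the starting number here is much higher. The size of the gain also carries over, and for these two pairs the effect of the exchange can be read without regard to which arrangement of the core is present: the same change on two cores in this assay, a 6.5-fold lower number (0.81 log units; beyond the scatter) from compound 1 to compound 2 and a 7.1-fold lower number (0.85 log units; beyond the scatter) from compound 3 to compound 4, 1.1-fold (0.04 log units) apart, within the scatter of two such steps.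

The entering group brings in a chlorine and a trifluoromethyl group together, so the compounds shown cannot say how much of the gain belongs to each, which a phenyl carrying only one of the two could help to separate. Also open, as far as these compounds go, is whether the two steps would still match with a different group on the sulfonyl sulfur, such as a simple amine, or with a longer chain linking the sulfonamide to the core.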